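Replacing methyl with phenyl in compound 3

A few compounds are considered here, and "the series" means these few. Any claim that something is new, unique, unknown or untested is made for them only; others in the source may bear on it.

Compound 1 `Nc1ncc(-c2ccc(F)cc2)c(C2CC2)n1`: > 100000 nM (a limit)
Compound 2 `Nc1ncc(-c2ccncc2-c2ccoc2)c(C2CC2)n1`: 28000 nM
Compound 3 `Cc1nc(N)ncc1-c1ccncc1`: > 100000 nM (a limit)

In a functional assay on CUTLL1 cells (Homo sapiens) for inhibition, read by resazurin assay, with a stated time of 48 h, in the absence of a further agent (on this read-out lower numbers stand for an effect already at smaller amounts and higher numbers for an effect only at larger amounts of compound), compound 3 stands at > 100000 nM, which is a limit of the assay and not a number. Compound 3 shares this position with compound 1: the limit of > 100000 nM in this assay, at which 2 of the 3 values shown sit. Compound 4 `Nc1ncc(-c2ccncc2)c(-c2ccccc2)n1` carries phenyl in place of methyl on an aromatic carbon. Going by the values given here, no measured pair isolates this change. Among the compounds with values here, compound 4 is expected to shift modestly towards smaller amounts, with compound 2 at 28000 nM as the only numerical guide. The estimated step is an at least 2.2-fold lower number from compound 3 to compound 4 (0.34 log units; beyond the scatter). For compound 4 the expected value is 45000 nM, with an estimated range of 15000 nM to 100000 nM.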

Compound 4, half-maximal effective concentration: > 100000 nM
Compound 4 was reported as a limit (the forecaster's own chance of this, stated with the estimate: 40%); at least 2.2-fold (0.34 log units) between middle value and limit.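

Compound 3 and compound 4 both stand at a limit of the assay, so no step can be read between them: the limit of > 100000 nM in this assay, at which 3 of the 4 values shown sit.

The compounds shown leave open what size of change, if any, phenyl in place of methyl on an aromatic carbon brings.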